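The source may report more compounds than this note shows. Statements on the series, on what has been measured and on what is new or still open speak of the compounds shown alone.

Compound 1 `COc1ccc(N(C)c2ccnc(Cl)n2)cc1Cl` and compound 2 `COc1ccc(N(C)c2ccnc(Cl)n2)cc1[N+](=O)[O-]` share a core and differ in one place: nitro in place of chloro on an aromatic carbon. In a functional assay on HepG2 cells (Homo sapiens) for antiproliferative activity, read by MTT assay, with a stated time of 48 h (a higher number here means a weaker inhibitor, a lower number a stronger inhibitor), compound 1 gives 2630 nM, and in the same assay compound 2 gives 6120 nM, a step of a 2.3-fold higher number from compound 1 to compound 2 (0.37 log units; beyond the scatter).

Compound 3 `COc1ccc(N(C)c2cc(C)nc(C)n2)cc1Cl` carries a different core; how its core differs from that of compound 1 is not broken down here. In this assay compound 3 gives 787 nM, the lowest of the three numbers.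

Compound 4 `COc1ccc(N(C)c2cc(C)nc(C)n2)cc1[N+](=O)[O-]` stands to compound 3 as compound 2 stands to compound 1: nitro in place of chloro on an aromatic carbon. The surroundings are described slightly differently, as meta to a large group rather than meta to a group of 9 heavy atoms, so this is the same kind of change. Because a 2.3-fold higher number from compound 1 to compound 2 (0.37 log units; beyond the scatter) was modest, compound 4 is expected to give a step of a 2.3-fold higher number from compound 3 to compound 4 (0.36 log units; beyond the scatter) in this assay. Compound 4 is therefore estimated at 1800 nM, with a likely range from 800 nM to 4500 nM.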

Compound 4, half-maximal inhibitory concentration: 2990 nM
Beside the measured number, compound 4's estimate is 1.7-fold (0.22 log units) below it; the range from low to high includes it.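

On the core of compound 3, nitro in place of chloro gives a 3.8-fold higher number from compound 3 to compound 4 (0.58 log units; beyond the scatter) in this assay and so moves the number the same way as on the core of compound 1. The two steps cannot be told apart in size: the same change on two cores in this assay, a 2.3-fold higher number (0.37 log units; beyond the scatter) from compound 1 to compound 2 and a 3.8-fold higher number (0.58 log units; beyond the scatter) from compound 3 to compound 4, 1.6-fold (0.21 log units) apart, within the scatter of two such steps. This shows the change carrying over between these two cores only; it does not show that it would hold on any further core, and it does not say why the number rises.

The compounds shown leave open what other groups in that place, such as a fluoro, a nitrile or an amine, would do. They also leave open whether an ethoxy or a hydroxy in place of the methoxy group would alter the step.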